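This account rests on a few compounds, and the source may have more. Where it says the series, first, only, none or still open, it means among the compounds named here.

The measured compounds are:

compound 1, `O=C(NCc1cc(Cl)ccc1-n1cnnn1)[C@@H]1CC=NN1C(=O)[C@H](O)c1ccccc1`, which gives 7 10^-6 cm/s in an ADME assay on Caco-2 cells (Homo sapiens) for permeability, read by LC-MS, in the apical to basolateral direction, with a stated time of 60 min, at pH 6.5; on this read-out lower numbers stand for lower permeability and higher numbers for higher permeability;
compound 2, `CC(C)(C)C[C@@H](O)C(=O)N1N=CC[C@H]1C(=O)NCc1cc(Cl)ccc1-n1cnnn1`, which gives 24 10^-6 cm/s in this assay;
compound 3, `O=C(NCc1cc(Cl)ccc1-n1cnnn1)[C@@H]1C[C@H]2C[C@H]2N1C(=O)[C@H](O)c1ccccc1`, which gives 17 10^-6 cm/s in this assay.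

Compound 4, `CC(C)(C)C[C@@H](O)C(=O)N1[C@@H]2C[C@@H]2C[C@H]1C(=O)NCc1cc(Cl)ccc1-n1cnnn1`, has not yet been measured in this assay. It is related to compound 3 by a single change, (neopentyl in place of phenyl on a saturated chain carbon bound to a carbonyl carbon and an oxygen on a saturated carbon), and that is the same change already seen between compound 1 and compound 2, neopentyl in place of phenyl on a saturated chain carbon bound to a carbonyl carbon and an oxygen on a saturated carbon: the two place descriptions agree word for word, so the change is the same one applied to a different core. How the core of compound 3 differs from the core of compound 1 is not broken down here; what can be said is that compound 3 gives a higher number than compound 1 in this assay, and that compound 3 and compound 2 lie within the scatter of each other.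

Going by the values given here, the one measured instance of the change produced a 3.4-fold higher number from compound 1 to compound 2 (0.54 log units; beyond the scatter). Since compound 3 already stands higher than compound 1, the same change applied to it is expected to give a step of roughly comparable size, estimated as a 2.4-fold higher number from compound 3 to compound 4 (0.37 log units; beyond the scatter), though some flattening at the upper end of this kind of read-out is possible. Compound 4 is therefore expected to give about 40 10^-6 cm/s in this assay, with an expected range from 20 10^-6 cm/s to 70 10^-6 cm/s.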

Compound 4, apparent permeability: 24 10^-6 cm/s
Beside the measured number, compound 4's estimate is 1.7-fold (0.22 log units) above it, and the stated range covers the measured number.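

Placed on the core of compound 3, neopentyl in place of phenyl gives a 1.4-fold higher number from compound 3 to compound 4 (0.15 log units; within the scatter) in this assay, so on this core the change does not stand clear of the scatter, whereas on the core of compound 1 it gave a 3.4-fold higher number from compound 1 to compound 2 (0.54 log units; beyond the scatter). Even so, the two steps cannot be told apart, so the result gives no evidence that the core alters what the change does: the same change on two cores in this assay, a 3.4-fold higher number (0.54 log units; beyond the scatter) from compound 1 to compound 2 and a 1.4-fold higher number (0.15 log units; within the scatter) from compound 3 to compound 4, 2.4-fold (0.39 log units) apart, within the scatter of two such steps This agreement rests on a single pair of compounds for each core, so it is compatible with a step that carries over between these two cores but does not establish one of fixed size, and it cannot say whether the step on the core of compound 3 is a real one or only scatter.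

The compounds shown leave open how the same change behaves on any further core, where a larger set of pairs would be needed to fix the size of the step. They also leave open what other groups would give in the same place, on a saturated chain carbon bound to a carbonyl carbon and an oxygen, such as a longer chain, an amine or a carboxylic acid.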